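Aryl substituent change on the shared core: fluoro to nitro

A few compounds are considered here, and "the series" means these few. Any claim that something is new, unique, unknown or untested is made for them only; others in the source may bear on it.

Measured so far:
Compound 1, `O=C1C2CCCCN2C(=O)N1CN1CCN(c2cccc(Cl)c2)CC1`, gives 135 nM in an assay on isolated protein for binding affinity to Adrenergic receptor alpha-1 (Rattus norvegicus), read by radioligand binding; a lower number here means a stronger inhibitor, a higher number a weaker inhibitor.
Compound 2, `O=C1C2CCCCN2C(=O)N1CN1CCN(c2ccc(F)cc2)CC1`, gives 869 nM in this assay.

In this assay compound 2 stands at the highest of the two numbers; its nearest neighbour is compound 1, and the step of a 6.4-fold higher number from compound 1 to compound 2 (0.81 log units; beyond the scatter) lies beyond the scatter. Compound 3, `O=C1C2CCCCN2C(=O)N1CN1CCN(c2ccc([N+](=O)[O-])cc2)CC1`, differs from compound 2 by nitro in place of fluoro on an aromatic carbon. Within the data shown here, no measured step exchanges the fluoro itself. The only step shown, a 6.4-fold higher number from compound 1 to compound 2 (0.81 log units; beyond the scatter), alters the substituent on the same phenyl ring together with its place, and it is modest. A step of that size or smaller is therefore expected here, with the direction left open by the data. Compound 3 is expected near 600 nM, with a range from 150 nM to 3000 nM. The expected step is a 1.4-fold lower number from compound 2 to compound 3 (0.16 log units; within the scatter), which stays within the scatter.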

Compound 3, inhibition constant: > 10000 nM
Compound 3 was reported as a limit; the forecaster's own chance of this, stated with the estimate: 5%; at least 16-fold (1.22 log units) between middle value and limit.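

In this assay compound 3 is reported only as a limit, not as a number: the limit of > 10000 nM in this assay, at which 1 of the 3 values shown sits. Even so, nitro in place of fluoro on the aromatic carbon para to a large group gives an at least 11-fold higher number from compound 2 to compound 3 (1.06 log units; beyond the scatter), so a change of substituent alone at this place moves the number by a large step. The change from the 3-chlorophenyl group to the 4-nitrophenyl group gives an at least 74-fold higher number from compound 1 to compound 3 (1.86 log units; beyond the scatter), which is wider than the modest 6.4-fold higher number from compound 1 to compound 2 (0.81 log units; beyond the scatter).

The compounds shown leave open whether an amine or a methoxy group on the same aromatic carbon would stay near compound 2 or follow compound 3. They also leave open how nitro would read in the place of the chloro of compound 1.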